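This account rests on a few compounds, and the source may have more. Where it says the series, first, only, none or still open, it means among the compounds named here.

The measured compounds, tested in a functional assay on KB cells (Homo sapiens) for antiproliferative activity, read by MTT assay, with a stated time of 72 h; a higher number here means a weaker inhibitor, a lower number a stronger inhibitor:

Compound 1, `CCOC(=O)c1cc(-c2cc(OC)c(OC)c(OC)c2)c(-c2ccc(OC)c(OCc3ccccc3)c2)s1`, gives a limit of the assay, > 100000 nM.
Compound 2, `COc1ccc(-c2sc(C(=O)O)cc2-c2cc(OC)c(OC)c(OC)c2)cc1OCc1ccccc1`, likewise gives only a limit, > 100000 nM.
Compound 3, `CCOC(=O)c1cc(-c2ccc(OC)cc2)c(-c2cc(OC)c(OC)c(OC)c2)s1`, gives 10200 nM.

Going by the values given here, two of the three values in this assay are limits, and compound 3 holds the only number among them. The step from compound 1 to compound 2, a step that the two limits leave unreadable from compound 1 to compound 2, is the change (hydrogen in place of ethyl on an oxygen next to a carbonyl group); the two limits leave its size unreadable, and this is the evidence on that point: the limit of > 100000 nM in this assay, at which 2 of the 3 values shown sit. The difference between the core of compound 1 and the core of compound 3 is not broken down here.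

Compound 4, `COc1ccc(-c2cc(C(=O)O)sc2-c2cc(OC)c(OC)c(OC)c2)cc1`, has not yet been measured. It differs from compound 3 by hydrogen in place of ethyl on an oxygen next to a carbonyl group, the same change as from compound 1 to compound 2, made here on the core of compound 3. The place of the change is the same in both pairs, on an oxygen next to a carbonyl group whose other neighbour is the carbonyl carbon.

The earlier step that the two limits leave unreadable from compound 1 to compound 2 could not be read, so the expectation for compound 4 rests mainly on where compound 3 stands, at 10200 nM. That number sits close to the upper edge of what this assay reports. Compound 4 is therefore expected at 80000 nM, within 15000 nM to 300000 nM, most likely reported only as a limit. The expected step from compound 3 is estimated as a 7.8-fold higher number from compound 3 to compound 4 (0.89 log units; beyond the scatter).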

Compound 4, half-maximal inhibitory concentration: 8650 nM
The estimate for compound 4 lay 9.2-fold (0.97 log units) above the measured number; measured number below the stated range.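

On the core of compound 3, putting hydrogen in place of ethyl on an oxygen next to a carbonyl group, which turns ethoxycarbonyl into carboxy, gives in this assay a 1.2-fold lower number from compound 3 to compound 4 (0.07 log units; within the scatter), so compound 3 and compound 4 cannot be told apart by this read-out. Going by these compounds alone, this is a single pair on a single core, and it shows only that on this core the ester and the acid read alike; it does not show that the change would read the same way on any other core. Within the data shown here, the same change on the core of compound 1 cannot be read, so the one readable step has no second step to be set beside, and carrying the change from one core to the other remains untested: the limit of > 100000 nM in this assay, at which 2 of the 4 values shown sit.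

The compounds shown leave open how other groups in place of the ethyl ester would read on the core of compound 3, such as a primary amide, a methyl ester or a longer chain on the same oxygen. They also leave open what separates the core of compound 1 from the core of compound 3, since those two compounds differ in more than one place.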